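The source may report more compounds than this note shows. Statements on the series, on what has been measured and on what is new or still open speak of the compounds shown alone.

Measured so far:
Compound 1, `COc1ccc(-n2cc(-c3ccccc3)c(-c3ccc4c(c3)NC(=O)CO4)n2)cc1`: 59.9%
Compound 2, `O=C1COc2ccc(-c3[nH]c(-c4c[nH]c5ncccc45)nc3-c3ccccc3)cc2N1`: 8.9%
Compound 3, `O=C1COc2ccc(-c3nn(-c4ccccc4)cc3-c3ccccc3)cc2N1`: 97.9%

In a functional assay on MV4-11 cells (Homo sapiens) for cytotoxicity, read by colorimetric assay and MTT assay, with a stated time of 3 days, tested at 20 uM (on this read-out lower numbers stand for a stronger effect and higher numbers for a weaker effect at the one concentration tested), compound 2 gives the lowest number of the three; compound 1 lies a good way above it and compound 3 further still, both gaps beyond the scatter. Compound 2 is thus the strongest of the measured set on this read-out.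

Compound 4, `O=C1COc2ccc(-c3[nH]c(-c4ccc(F)cc4)nc3-c3ccccc3)cc2N1`, is not yet measured. It differs from compound 2 as follows: a group of 7 heavy atoms (6 carbon, 1 fluorine; one six-membered aromatic ring of carbon only) in place of a group of 9 heavy atoms (7 carbon, 2 nitrogen; one five-membered aromatic ring with 1 hetero atom, one six-membered aromatic ring with 1 hetero atom), on an aromatic carbon. The group that enters, 4-fluorophenyl, carries no hydrogen-bond donor or acceptor, where the group that leaves carries one of each.

Within the data shown here, only one measured step is available, a number 38 percentage points higher from compound 1 to compound 3 (beyond the scatter), and it concerns a different place on a different core, so it does not bear directly on the change from compound 2 to compound 4. It does show that a single small change can move this read-out by a large amount. Among the measured compounds shown here, with no measured analogue of compound 2 at the carbon between two ring nitrogen atoms, the expectation is uncertain; the loss of the group with a donor and an acceptor is taken to weaken the effect. The step from compound 2 to compound 4 is expected to be a number 36.1 percentage points higher from compound 2 to compound 4 (beyond the scatter). For compound 4 the estimate is 45%, with a range from 10% to 90%.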

Compound 4, a percentage reported as activity, at one concentration (the size of the read-out at that concentration, not a potency): 1.1%
The estimate for compound 4 lay 43.9 percentage points above the measured number, outside the stated range (below it).
By their numbers in this assay, from the lowest: compounds 4 and 2 (each within the scatter of the next); then compound 1; then compound 3.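

In this assay, the change on the aromatic carbon between two ring nitrogen atoms gives a number 7.8 percentage points lower from compound 2 to compound 4 (within the scatter), so this pair does not separate 4-fluorophenyl from the larger group it replaces. At this position, in this pair, the effect on the read-out does not depend on the hydrogen-bond donor and acceptor of the leaving group, or on its five-membered aromatic ring, since 4-fluorophenyl has neither the donor and acceptor nor such a ring. No measured evidence on the cause of this result is available.

On these data alone, with one concentration per compound, any difference in potency between compound 2 and compound 4 remains open, since a single-concentration read-out does not give a potency. Among these compounds, also open is how far this carbon accepts groups of another kind, such as an unsubstituted phenyl, a carboxylic acid, an amine or a longer alkyl chain, and whether the same freedom would hold on the core of compound 1, where the only other measured step lies.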